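Shifting one trifluoromethyl group in compound 3

A few compounds are considered here, and "the series" means these few. Any claim that something is new, unique, unknown or untested is made for them only; others in the source may bear on it.

compound 1 `CC(O)(CSc1cccc(S(F)(F)(F)(F)F)c1)C(=O)Nc1ccc(C#N)cc1C(F)(F)F` gives 37400 nM
compound 2 `CC(O)(COc1ccc(S(F)(F)(F)(F)F)cc1)C(=O)Nc1cccc(S(F)(F)(F)(F)F)c1` gives 12800 nM
compound 3 `CC(O)(COc1ccc(C(F)(F)F)cc1)C(=O)Nc1cccc(S(F)(F)(F)(F)F)c1` gives 13600 nM

These three numbers come from a functional assay on DU-145 cells (Homo sapiens) for antiproliferative activity, read by propidium iodide staining, with a stated time of 96 h; a lower number here means a stronger inhibitor, a higher number a weaker inhibitor. Compound 3 sits with compound 2, the two values lying within the scatter of each other. Compound 1 stands apart with a higher number, beyond the scatter, and so is a weaker inhibitor than compound 3.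

The next compound, compound 4 `CC(O)(COc1ccccc1C(F)(F)F)C(=O)Nc1cccc(S(F)(F)(F)(F)F)c1`, has the same atoms as compound 3, joined differently (2-(trifluoromethyl)phenyl in place of 4-(trifluoromethyl)phenyl on an oxygen on a saturated carbon). In words, it carries 2-(trifluoromethyl)phenyl in place of 4-(trifluoromethyl)phenyl on an oxygen on a saturated carbon.

Among the compounds with values here, only one measured step bears on this change. It is a 1.1-fold higher number from compound 2 to compound 3 (0.03 log units; within the scatter), an exchange of one group for another on that same aromatic ring, and it stayed within the scatter. Compound 1 differs from compound 3 in more than one place, so it offers no clean comparison. No measurement here shows what moving a group around that ring does, so the guidance is indirect and the uncertainty is wide.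

In this assay no step beyond the scatter is expected, in either direction. The expected step is a 1.1-fold higher number from compound 3 to compound 4 (0.03 log units; within the scatter). For compound 4 the estimated value is 14500 nM, with an expected range of 6000 nM to 35000 nM.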

Compound 4, half-maximal inhibitory concentration: 52200 nM
Compound 4: the middle estimate sits 3.6-fold (0.56 log units) below what was measured; the measured number lies above the stated range.
By their numbers in this assay, from the lowest: compounds 2 and 3 (each within the scatter of the next); then compounds 1 and 4 (each within the scatter of the next).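

In this assay, placing 2-(trifluoromethyl)phenyl in place of 4-(trifluoromethyl)phenyl on an oxygen on a saturated carbon gives a 3.8-fold higher number from compound 3 to compound 4 (0.58 log units; beyond the scatter). Within the data shown here, the two groups have the same atoms and the same counts, so this is the first sign that where the trifluoromethyl group sits on this ring matters here, whereas exchanging one group for another on that ring gave only a 1.1-fold higher number from compound 2 to compound 3 (0.03 log units; within the scatter). Nothing available explains why the number rises with this shift.

From the compounds shown here alone, whether a plain phenyl ring, or a ring carrying a chlorine atom or a methoxy group instead of the trifluoromethyl group, would give a number close to that of compound 3 or to that of compound 4 stays open. Also open, going by these compounds, is whether the same shift would raise the number in a compound built like compound 1, which differs from compound 3 in more than one place.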